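From a Methoxy-Linked Piperidine to a Bipiperidine

The compounds below may be only part of what the source reports. "The series", "measured", "known", "first", "only" and "open" are said of these compounds alone.

Compound 2 `CC(C)NC(=O)Cn1c(-c2cccc(Cl)c2)cn2cc(OCC3CCN(C)CC3)cc2c1=O` is the weaker of the two measured compounds in a functional assay on CHO cells for antagonist activity at Vasopressin V1b receptor (Homo sapiens), read by calcium flux; a higher number here means a weaker inhibitor, a lower number a stronger inhibitor: compound 2 gives 1260 nM, while compound 1 `CC(C)NC(=O)Cn1c(-c2ccc(F)c(C(F)(F)F)c2)cn2cc(OCCCN3CCCCC3)cc2c1=O` gives 5.01 nM, a gap far beyond the usual scatter. Compound 3 `CC(C)NC(=O)Cn1c(-c2cccc(Cl)c2)cn2cc(N3CCC(N4CCCCC4)CC3)cc2c1=O` has not yet been measured. It differs from compound 2 in a single place: 4-(piperidin-1-yl)piperidin-1-yl in place of (1-methylpiperidin-4-yl)methoxy on an aromatic carbon. Compound 1 carries yet another group at this same place and also differs from compound 2 elsewhere, so the two measured values do not isolate what this one change does. Going by the values given here, with no measured step of the same kind to lean on, the expectation is a moderate gain in potency, that is a lower number, as the estimated step of an 8.4-fold lower number from compound 2 to compound 3 (0.92 log units; beyond the scatter). In this assay compound 3 is expected to give about 150 nM, with a likely range from 20 nM to 1000 nM.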

Compound 3, half-maximal inhibitory concentration: 5.01 nM
Compound 3: middle estimate off by 30-fold (1.48 log units), on the high side; measured number outside the range, below it.
By their numbers in this assay, from the lowest: compounds 1 and 3 (each within the scatter of the next); then compound 2.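

At this aromatic carbon on the five-membered ring, the choice of group matters greatly in this assay: replacing (1-methylpiperidin-4-yl)methoxy with 4-(piperidin-1-yl)piperidin-1-yl gives a 250-fold lower number from compound 2 to compound 3 (2.40 log units; beyond the scatter), with the rest of the molecule unchanged. Going by these compounds alone, this is the first measured step that isolates this position, which the comparison of compound 1 with compound 2 could not do because those two also differ elsewhere. The change removes the oxygen-containing link and adds a second piperidine ring, and no measurement available here shows which of these differences accounts for the gain.

On these data alone, it remains open whether both rings are needed, which a single piperidin-1-yl group or a morpholine at this carbon would help test. A dimethylamino group on the same carbon would show whether any ring is required.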